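The source may hold more compounds than are shown below. What is called first, only, known or untested is meant among the compounds shown, and "the series" means these compounds.

Measured so far:
compound 1, `CN(C)CCn1nc(Cc2ccc(Cl)cc2)c2ccccc2c1=O`, 158 nM
compound 2, `O=c1c2ccccc2c(Cc2ccc(Cl)cc2)nn1C[C@H]1CCCN1CCCCCc1ccc(OCCCN2CCCCCC2)cc1`, 25.1 nM
compound 3, `CCCCCc1nn(C[C@H]2CCCN2C)c(=O)c2ccccc12`, 501 nM

All three numbers come from an assay for binding affinity to Alpha-1A adrenergic receptor (Homo sapiens); a higher number here means a weaker inhibitor, a lower number a stronger inhibitor. Compound 3 stands at the highest number of the three; its nearest neighbour is compound 1, and both compound 1 and compound 2 sit beyond the scatter below it. Compound 2 lies furthest from it. Within the data shown here, no pair among the three differs in a single place, so no clean step can be read from the measured set; what can be said is that compounds 1 and 2, which both carry an aromatic ring on the chain carbon where compound 3 has its pentyl, both give lower numbers than compound 3.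

Compound 4, `CN1CCC[C@@H]1Cn1nc(Cc2ccc(O)cc2)c2ccccc2c1=O`, is the next compound to be measured in this assay . Against compound 3 the change is 4-hydroxyphenyl in place of butyl on a saturated chain carbon bound to an aromatic carbon. It brings a ring with one hydrogen-bond donor and one hydrogen-bond acceptor in place of an open chain without either.

Given that compound 1 gives 158 nM and compound 2 gives 25.1 nM with an aromatic ring at this place, the expectation is a modest step downward, somewhat beyond the scatter, a 2.5-fold lower number from compound 3 to compound 4 (0.40 log units; beyond the scatter). The estimate for compound 4 in this assay is 200 nM, expected between 60 nM and 700 nM.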

Compound 4, inhibition constant: 251 nM
The estimate for compound 4 lay 1.3-fold (0.10 log units) below the measured number; the range from low to high includes it.
By their numbers in this assay, from the lowest: compound 2; then compounds 1, 4 and 3 (each within the scatter of the next, the first and the last beyond it).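

In this assay, 4-hydroxyphenyl in place of butyl on a saturated chain carbon bound to an aromatic carbon gives a 2.0-fold lower number from compound 3 to compound 4 (0.30 log units; within the scatter), the only comparison among the compounds shown that isolates a change at one place. At this place, the assay therefore does not separate the open chain from a ring carrying one hydrogen-bond donor and one hydrogen-bond acceptor. The earlier impression that an aromatic ring here goes with a lower number came from compounds differing in more than one place, and this single-place step gives it no support; no measurement at hand bears on why the step stays within the scatter.

Still open, as far as these compounds go, is whether the ring and its hydroxyl count separately at this place, a question that plain phenyl or 4-methoxyphenyl in place of 4-hydroxyphenyl would address. Also open, from the compounds shown here alone, is whether the open chain has any length dependence here, which a heptyl chain in place of pentyl would test on the same core.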